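Fluoro for amino: a step hidden by the assay limit

The source may hold more compounds than are shown below. What is called first, only, known or untested is meant among the compounds shown, and "the series" means these compounds.

Compound 1 `CC(=O)OC(C)n1cnc2c(S)nc(N)nc21` is tested in a functional assay on HT-29 cells (Homo sapiens) for inhibition; a higher number here means a weaker inhibitor, a lower number a stronger inhibitor. For compound 1 the assay reports only a limit, > 500000 nM. Compound 3 `CC(=O)OC(C)n1cnc2c(S)nc(F)nc21` differs from compound 1 by fluoro in place of amino on an aromatic carbon. Compound 3 likewise returns only a limit, > 500000 nM. The step that the two limits leave unreadable from compound 1 to compound 3 therefore has no readable size. Compound 2 `CC(=O)OCCOn1cnc2c(S)nc(N)nc21` carries a different core; the difference between the two cores is not broken down here. Compound 2 also sits at a limit, > 500000 nM. Compound 4 `CC(=O)OCCOn1cnc2c(S)nc(F)nc21` is not yet measured and differs from compound 2 by fluoro in place of amino on an aromatic carbon, the same change as from compound 1 to compound 3. Given (the limit of > 500000 nM in this assay, at which 3 of the 3 values shown sit), the expected step of a number no higher from compound 2 to compound 4 (the limit leaves the size open) rests only on that earlier unreadable step. Compound 4 is expected to give 500000 nM in this assay, most likely again only a limit, with an estimated range from 100000 nM to 2000000 nM.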

Compound 4, half-maximal inhibitory concentration: > 500000 nM
Compound 4 ended at the assay's limit; the forecaster's own chance of this, stated with the estimate: 85%; the middle value lies on the limit itself.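

No step can be read from compound 2 to compound 4, as both values are only limits: the limit of > 500000 nM in this assay, at which 4 of the 4 values shown sit.

On these data alone, whether fluoro in place of amino changes inhibition on either core stays open.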